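The compounds below may be only part of what the source reports. "The series", "measured", "known", "first", "only" and "open" are said of these compounds alone.

Compound 1, `Nc1scc(CN2CCN(c3ccc([N+](=O)[O-])cc3)CC2)c1C(=O)c1ccc(Cl)cc1`, was examined in a functional assay on CHO cells with adenosine receptor A1 (Homo sapiens) as the target, read by cAMP accumulation and immunoassay, with a stated time of 6 min, tested at 0.1 uM (a lower number here means a stronger effect, a higher number a weaker effect of the compound at the concentration tested), and gave -13%. Compound 2, `Nc1scc(CN2CCN(c3cccc(F)c3)CC2)c1C(=O)c1cccc(C(F)(F)F)c1`, was examined in the same this assay and gave -12%. Compound 1 holds the lowest of the two numbers recorded so far, yet its nearest neighbour, compound 2, sits within the scatter of it, so the two values show no reliable difference; both lie close to zero. Compound 3, `Nc1scc(CN2CCN(C3CCCCCC3)CC2)c1C(=O)c1ccc(Cl)cc1`, has not yet been measured in this assay. It differs from compound 1 in one place: cycloheptyl in place of 4-nitrophenyl on an amine nitrogen in a ring. Among the measured compounds shown here, no step between measured compounds that differ in one place is available, so the recorded numbers give no direction for this change. Because compound 1 gives -13% and compound 2 gives -12%, both near zero, the estimated step of a number 5 percentage points higher from compound 1 to compound 3 (within the scatter) in this assay is expected to stay within the scatter, with no clear direction. Compound 3 is estimated at -8% in this assay, with an expected range from -25% to 10%.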

Compound 3, a percentage reported as activity, at one concentration (the size of the read-out at that concentration, not a potency): 13%
The estimate for compound 3 lay 21 percentage points below the measured number; the whole stated range lies below it.
By their numbers in this assay, from the lowest: compounds 1 and 2 (each within the scatter of the next); then compound 3.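

Among the compounds shown here, with the rest of compound 1 held fixed, cycloheptyl in place of 4-nitrophenyl on an amine nitrogen in a ring gives a number 26 percentage points higher from compound 1 to compound 3 (beyond the scatter) in this assay, the first sign that the group at this position can move the read-out by more than the scatter. The change takes compound 3 to 13%, on the positive side of zero, whereas compound 1 gives -13%, so at the concentration tested the cycloheptyl compound has the weaker effect. Nothing measured here accounts for this step, which rests on a single pair of compounds.

The swap removes the nitro group and the aromatic ring and brings in a seven-membered non-aromatic ring of carbon all at once, so the compounds shown leave open which of these differences matters, a question that an unsubstituted phenyl group at the same position would help to separate. They also leave open whether the size of the carbon ring or its closure counts, as a cyclopentyl group or an open n-heptyl chain in place of cycloheptyl could show.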